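From hydroxy to acetoxy in a cytotoxicity series

The source may hold more compounds than are shown below. What is called first, only, known or untested is meant among the compounds shown, and "the series" means these compounds.

Of the compounds shown here, two with a shared core have been tested in a functional assay on HeLa cells (Homo sapiens) for cytotoxicity; a lower number here means a stronger inhibitor, a higher number a weaker inhibitor. Compound 1 (`COc1ccc(C(O)c2ccc3ccccc3c2)c(OC)c1OC`) carries a hydroxy group on a saturated carbon. Compound 1 gives > 10000 nM in this assay, which is a limit of the assay and not a number. Compound 2 (`COc1ccc(C(=O)c2ccc3ccccc3c2)c(OC)c1OC`) has a carbonyl there instead, and compound 2 gives a true number, 1700 nM.

Compound 3 (`COc1ccc(C(OC(C)=O)c2ccc3ccccc3c2)c(OC)c1OC`) has yet to be measured. It departs from compound 1 by a single change, hydroxy to acetoxy: acetyl in place of hydrogen on an oxygen on a saturated carbon. Going by the values given here, no measured pair shows what this change does, so any expectation is uncertain, and the limit for compound 1 leaves the starting point open. Compound 3 keeps the saturated carbon of compound 1 and lacks the carbonyl link of compound 2, which has 1700 nM, so it is expected to stay weak. The expected change is modest, towards stronger inhibition if it is visible at all: an at least 1.2-fold lower number from compound 1 to compound 3 (0.09 log units; that floor lies within the scatter). Compound 3 is estimated at 8000 nM, with an expected range from 2500 nM to 25000 nM.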

Compound 3, half-maximal inhibitory concentration: 2700 nM
Compound 3: the middle estimate sits 3.0-fold (0.47 log units) above what was measured; low and high end bracket the measured number.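

Replacing the hydrogen on the oxygen with acetyl yields a true number: in this assay, compound 3 gives 2700 nM. Compound 1 gives > 10000 nM, which is a limit of the assay and not a number. The change from hydroxy to acetoxy therefore produces an at least 3.7-fold lower number from compound 1 to compound 3 (0.56 log units; beyond the scatter), which shows that the group on this oxygen matters even with the saturated carbon kept in place, and this size is only a floor because the starting value is a limit: the limit of > 10000 nM in this assay, at which 1 of the 3 values shown sits.

The compounds shown leave open how much of the step comes from removing the hydroxy hydrogen and how much from the acetyl group itself, since a methyl group on the same oxygen would separate the two. They also leave open whether a longer acyl chain such as butanoyl on that oxygen, or an amine in place of the oxygen on the saturated carbon, would give a value like that of compound 3 or fall back to a limit.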